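Acetamido in Place of Nitro: An Expected Modest Gain

The source may report more compounds than this note shows. Statements on the series, on what has been measured and on what is new or still open speak of the compounds shown alone.

Measured in an assay on COS-7 cells for inhibition of patatin-like phospholipase domain-containing protein 2 (Mus musculus), tested at 200 uM; on this read-out higher numbers stand for more inhibition at the one concentration tested (going by the name of the read-out) and lower numbers for less inhibition:
compound 1 `CCOc1ccc(-c2ccccc2)cc1` gives 35%
compound 2 `CCOc1ccc(-c2cccc(C(=O)N3CCCC3)c2)cc1` gives 53%
compound 3 `CCOc1ccc(-c2cccc([N+](=O)[O-])c2)cc1` gives 35%

Compound 3 stands level with compound 1 at the digits shown, the two together lowest of the three; the step of no change at the digits printed from compound 1 to compound 3 (within the scatter) lies within the scatter. Among the measured compounds shown here, the only larger value belongs to compound 2, and the step of a number 18 percentage points lower from compound 2 to compound 3 (beyond the scatter) falls beyond the scatter.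

Compound 4 `CCOc1ccc(-c2cccc(NC(C)=O)c2)cc1` differs from compound 3 by acetamido in place of nitro on an aromatic carbon. For the measured compounds named here, two steps bear on this: the nitro group left the number of compound 1 unchanged, while the carbonyl-bearing group of compound 2 raised it modestly. Acetamido also carries a carbonyl, so a modest rise in this assay is expected, a number 9 percentage points higher from compound 3 to compound 4 (within the scatter). Compound 4 is estimated at 44%, between 30% and 60%.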

Compound 4, a percentage reported as inhibition, at one concentration (the size of the read-out at that concentration, not a potency): 52%
Beside the measured number, compound 4's estimate is 8 percentage points below it, and the stated range covers the measured number.
By their numbers in this assay, from the lowest: compounds 1 and 3 (each within the scatter of the next); then compounds 4 and 2 (each within the scatter of the next).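

On the shared core, acetamido in place of nitro raises the number (a number 17 percentage points higher from compound 3 to compound 4 (beyond the scatter)), and acetamido in place of hydrogen does the same (a number 17 percentage points higher from compound 1 to compound 4 (beyond the scatter)). Acetamido in place of (pyrrolidin-1-yl)carbonyl leaves the two values level (a number 1 percentage points lower from compound 2 to compound 4 (within the scatter)), so two different carbonyl-bearing groups now give matching numbers at this position. No evidence here gives a reason for this result.

Going by these compounds, whether the carbonyl itself is what these two groups share in effect stays open. An amine or a carboxylic acid at this position, or a longer chain in place of the acetamido methyl, would help to settle that.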